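Dropping the Fluoro: From Compound 3 to Compound 4

The compounds below may be only part of what the source reports. "The series", "measured", "known", "first", "only" and "open" are said of these compounds alone.

Measured so far in a functional assay on MCF7 cells (Homo sapiens) for antiproliferative activity, read by MTT assay, with a stated time of 72 h; on this read-out higher numbers stand for weaker inhibition and lower numbers for stronger inhibition:
Compound 1 `COc1cc(-n2ncnc2-c2cccc([N+](=O)[O-])c2)cc(OC)c1OC` gives > 10000 nM, a limit of the assay.
Compound 2 `COc1cc(-n2ncnc2-c2ccc(C)cc2)cc(OC)c1OC` gives 540 nM.
Compound 3 `COc1cc(-n2ncnc2-c2cccc(F)c2)cc(OC)c1OC` gives > 10000 nM, again a limit.

Compound 3 thus stands at the limit, without a number of its own, sharing that position with compound 1 (the limit of > 10000 nM in this assay, at which 2 of the 3 values shown sit). The step from compound 1 to compound 3 reads a step that the two limits leave unreadable from compound 1 to compound 3. Among the compounds with values here, the one readable step into compound 3 is an at least 18-fold higher number from compound 2 to compound 3 (1.26 log units; beyond the scatter). Compound 4 `COc1cc(-n2ncnc2-c2ccccc2)cc(OC)c1OC` differs from compound 3 in one place: hydrogen in place of fluoro on an aromatic carbon. This only partly undoes the large step that took compound 2 to the limit, so a move in the opposite direction, toward a readable number, is expected, though short of the value of compound 2. The expected step is an at least 3.3-fold lower number from compound 3 to compound 4 (0.52 log units; beyond the scatter). Compound 4 is estimated at 3000 nM, between 500 nM and 20000 nM.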

Compound 4, half-maximal inhibitory concentration: > 10000 nM
Compound 4: no number, only a limit (the forecaster's own chance of this, stated with the estimate: 40%); middle value at least 3.3-fold (0.52 log units) away from the limit.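

In this assay compound 4 also gives only a limit, so taking away the fluoro brings no readable number, and the steps among compound 1, compound 3 and compound 4 cannot be read: the limit of > 10000 nM in this assay, at which 3 of the 4 values shown sit.

Hydrogen in place of the methyl of compound 2 gives an at least 18-fold higher number from compound 2 to compound 4 (1.26 log units; beyond the scatter). Of the changes shown, only the methyl goes with a readable number, whether or not fluoro is present on the phenyl of the other compounds.

How far compound 3 and compound 4 lie apart stays hidden behind the limit. From the compounds shown here alone, whether an ethyl, a methoxy or a chlorine in the place of that methyl also gives a readable number remains open.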